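A few compounds are considered here, and "the series" means these few. Any claim that something is new, unique, unknown or untested is made for them only; others in the source may bear on it.

Compound 1, with the structure `CC(C)CCCC(C)CCCC(C)CCCC1(C)CCc2cc(OCC(=O)O)c(F)cc2O1`, and compound 2, with the structure `Cc1c(C)c2c(c(C)c1OCC(=O)O)CC[C@](C)(COCCC(C)CCCC(C)CCCC(C)C)O2`, were both tested in a functional assay on MCF7 cells (Homo sapiens) for activation, read by flow cytometry and annexin V staining; on this read-out higher numbers stand for an effect only at larger amounts of compound and lower numbers for an effect already at smaller amounts. In this assay compound 1 gives 60000 nM, while compound 2 gives 29000 nM, the lowest of the two numbers, and the gap between them lies beyond the usual scatter. Compound 3, with the structure `Cc1c(C)c2c(c(C)c1OCC(=O)O)CC[C@@](C)(COCCC(C)CCCC(C)CCCC(C)C)O2`, is the next compound: the two compounds have the same atoms and bonds; at least one stereo element is drawn with a configuration in one of them and without one in the other: 1 of 3 stereo elements differ; a stereocentre at a saturated ring carbon is drawn R in compound 2 and S in compound 3. For the measured compounds named here, no step between measured compounds exists to guide this change, so a step of only modest size, if any, is expected, a 1.4-fold higher number from compound 2 to compound 3 (0.14 log units; within the scatter). For compound 3 the expected value is 40000 nM, estimated to fall between 15000 nM and 120000 nM.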

Compound 3, half-maximal effective concentration: 21000 nM
Beside the measured number, compound 3's estimate is 1.9-fold (0.28 log units) above it, within the range that was stated.
By their numbers in this assay, from the lowest: compounds 3 and 2 (each within the scatter of the next); then compound 1.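

Changing the drawn configuration at the saturated ring carbon from R in compound 2 to S in compound 3 gives a 1.4-fold lower number from compound 2 to compound 3 (0.14 log units; within the scatter), so this single stereocentre shows no clear influence on the number. For the compounds shown here, this is the only change here confined to one place, which the earlier pair could not offer. Even this reading needs caution because of one fact: the fact that one of compounds 2 and 3 is drawn with a defined configuration and the other without, at the place where they differ

The compounds shown leave open whether this stereocentre would matter with a different group on that ring carbon, such as an amine in place of the ether-linked chain.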